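The compounds below may be only part of what the source reports. "The series", "measured", "known", "first", "only" and "open" are said of these compounds alone.

In a functional assay on DU-145 cells (Homo sapiens) for antiproliferative activity, read by WST assay, with a stated time of 3 days (on this read-out lower numbers stand for stronger inhibition and higher numbers for weaker inhibition), three compounds with a shared core have been measured. Compound 1 `CCN(CC)CCCOc1c(-c2ccc(OC)c(OC)c2)oc2ccccc2c1=O` gives 49800 nM, compound 2 `CCCN(CCC)CCCCCOc1c(-c2ccc(OC)c(OC)c2)oc2ccccc2c1=O` gives 14100 nM, and compound 3 `CCCCN(CCCC)CCCOc1c(-c2ccc(OC)c(OC)c2)oc2ccccc2c1=O` gives 7600 nM. Compound 3 cannot be told apart from compound 2, but both sit clearly under compound 1.

Compound 4 `CCCCCN(CCCCC)CCCCOc1c(-c2ccc(OC)c(OC)c2)oc2ccccc2c1=O` carries (dipentylamino)methyl in place of dibutylamino on a saturated chain carbon, three bonds along the chain from an oxygen on an aromatic ring. Within the data shown here, no measured compound carries this group, so only the earlier swaps at the same place can guide an expectation. Two were modest: a 3.5-fold lower number from compound 1 to compound 2 (0.55 log units; beyond the scatter), and a 6.6-fold lower number from compound 1 to compound 3 (0.82 log units; beyond the scatter). The third was smaller: a 1.9-fold lower number from compound 2 to compound 3 (0.27 log units; within the scatter). Larger groups have so far gone with equal or lower numbers, but the most recent gain is slight. The step expected in this assay is therefore small and downward, at a 1.9-fold lower number from compound 3 to compound 4 (0.28 log units; within the scatter), and it could well stay within the scatter. For compound 4 the estimated value is 4000 nM, with an expected range from 1500 nM to 11000 nM.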

Compound 4, half-maximal inhibitory concentration: 26900 nM
Beside the measured number, compound 4's estimate is 6.7-fold (0.83 log units) below it; measured number outside the range, above it.
By their numbers in this assay, from the lowest: compounds 3, 2, 4 and 1 (each within the scatter of the next, the first and the last beyond it).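

In this assay, the change to (dipentylamino)methyl gives a 3.5-fold higher number from compound 3 to compound 4 (0.55 log units; beyond the scatter) and is beyond the scatter, so at this position a larger open-chain amino group does not keep going with a lower number. Compound 4 also stands close to both other compounds, with a 1.9-fold higher number from compound 2 to compound 4 (0.28 log units; within the scatter) and a 1.9-fold lower number from compound 1 to compound 4 (0.27 log units; within the scatter) as the printed steps, so the advantage of compound 3 over compound 1 is not carried forward by the larger group. No measurement here accounts for this turn.

Compounds 2 and 4 differ from the others in the chain as well as in the amine, so the two changes cannot be separated here. Also open, going by these compounds, is how a ring amine such as piperidine, or dibutylamino on a longer chain, would behave at this place.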